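Clearance on replacing the pyrazole of compound 1

A few compounds are considered here, and "the series" means these few. Any claim that something is new, unique, unknown or untested is made for them only; others in the source may bear on it.

Measured in an ADME assay on microsomes from liver (Homo sapiens) for pharmacokinetics; a higher number here means faster removal of the compound, a lower number slower removal:
- compound 1 `Cc1c(Nc2nc(N)c3c(C#N)c(N4CCC[C@H]4C)n(C)c3n2)cnn1C`: 41.7 mL/min/kg
- compound 2 `C[C@@H]1CCCN1c1c(C#N)c2c(N)nc(Nc3cn(C)nc3Cl)nc2n1C`: 183 mL/min/kg
- compound 3 `Cc1c(Nc2nc(N)c3c(C#N)c(N4CCC[C@H]4C)n(C)c3n2)cnn1[C@@H]1CCOC1`: 28.3 mL/min/kg

Compound 1 and compound 3 lie within the scatter of each other at the low end of these three numbers, and only compound 2 stands clearly apart.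

Compound 4 `C[C@@H]1CCCN1c1c(C#N)c2c(N)nc(Nc3cn(C)nc3C(F)(F)F)nc2n1C` has not yet been measured. Its difference from compound 1 is 1-methyl-3-(trifluoromethyl)-1H-pyrazol-4-yl in place of 1,5-dimethyl-1H-pyrazol-4-yl on a nitrogen on an aromatic ring. The 1-methyl-3-(trifluoromethyl)-1H-pyrazol-4-yl group enters in place of 1,5-dimethyl-1H-pyrazol-4-yl on a nitrogen on an aromatic ring.

For the measured compounds named here, the closest precedent is a 4.4-fold higher number from compound 1 to compound 2 (0.64 log units; beyond the scatter), where 3-chloro-1-methyl-1H-pyrazol-4-yl enters at that same place. The other step, a 1.5-fold lower number from compound 1 to compound 3 (0.17 log units; within the scatter), changes a different group and offers little guidance. Going by the values given here, no measured compound carries trifluoromethyl, so this single precedent supports only a cautious expectation of a rise in this assay beyond the scatter, probably smaller than the one seen for the chloro group.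

For compound 4 the expected step is a 2.6-fold higher number from compound 1 to compound 4 (0.42 log units; beyond the scatter).

For compound 4 the estimated value is 110 mL/min/kg, with an expected range of 45 mL/min/kg to 240 mL/min/kg.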

Compound 4, clearance: 33.3 mL/min/kg
For compound 4 the middle estimate is 3.3-fold (0.52 log units) above the measured one; the whole stated range lies above it.
By their numbers in this assay, from the lowest: compounds 3, 4 and 1 (each within the scatter of the next); then compound 2.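

In this assay, replacing 1,5-dimethyl-1H-pyrazol-4-yl does not in itself carry a penalty: a 1.3-fold lower number from compound 1 to compound 4 (0.10 log units; within the scatter) shows that 1-methyl-3-(trifluoromethyl)-1H-pyrazol-4-yl leaves the number level with the starting point. The direct comparison, a 5.5-fold lower number from compound 2 to compound 4 (0.74 log units; beyond the scatter), isolates trifluoromethyl in place of chloro on an aromatic carbon and ties the high clearance among these pyrazoles to compound 2 alone. Nothing shown here explains why these two groups part so widely.

Open, as far as these compounds go, is how a methoxy, cyclopropyl or fluoro group on that aromatic carbon would behave, and whether it would stay with compound 4 or rise towards compound 2. Also open, from the compounds shown here alone, is whether trifluoromethyl keeps this result when oxolan-3-yl replaces methyl on the aromatic nitrogen.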